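The source may report more compounds than this note shows. Statements on the series, on what has been measured and on what is new or still open speak of the compounds shown alone.

Measured so far in an ADME assay on the whole organism (Rattus norvegicus, strain Sprague-Dawley) for pharmacokinetics, read by LC-MS, at a dose of 1 mg/kg by the intravenous route; on this read-out higher numbers stand for fast clearance and lower numbers for slow clearance:
- compound 1 `Cc1nc(C)c([C@H](OC(C)(C)C)C(=O)O)c(N2CCC(C)(C)CC2)c1-c1ccc2c(c1)CCN(Cc1cccc(F)c1C)C2`: 4 mL/min/kg
- compound 2 `Cc1nc(C)c([C@H](OC(C)(C)C)C(=O)O)c(N2CCC(C)(C)CC2)c1-c1ccc2c(c1)CCN(Cc1cccc(F)c1F)C2`: 8.1 mL/min/kg

Compound 2 stands highest of these two. Compound 3 `Cc1nc(C)c([C@H](OC(C)(C)C)C(=O)O)c(N2CCC(C)(C)CC2)c1-c1ccc2c(c1)CCN(c1nccc(-c3cnccn3)n1)C2` carries a group of 12 heavy atoms (8 carbon, 4 nitrogen; 2 six-membered aromatic rings with 2 hetero atoms each) in place of a group of 9 heavy atoms (7 carbon, 2 fluorine; one six-membered aromatic ring of carbon only), on an amine nitrogen in a ring. Going by the values given here, one measured step bears on this, a 2.0-fold higher number from compound 1 to compound 2 (0.31 log units; beyond the scatter), a modest step just beyond the scatter that swaps fluoro for methyl on an aromatic carbon. Among the compounds with values here, no measured step replaces the whole group on that nitrogen, so no direction can be drawn from the data. On this assay, the expected change is a 1.4-fold lower number from compound 2 to compound 3 (0.13 log units; within the scatter), which is no step beyond the scatter. Compound 3 is expected at 6 mL/min/kg, with an estimated range of 2 mL/min/kg to 18 mL/min/kg.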

Compound 3, clearance: 2.1 mL/min/kg
The estimate for compound 3 lay 2.9-fold (0.46 log units) above the measured number; the range from low to high includes it.
By their numbers in this assay, from the lowest: compounds 3 and 1 (each within the scatter of the next); then compound 2.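

In this assay the amine nitrogen in a ring tolerates exchange of the whole group, not only of a substituent on it: the step is a 3.9-fold lower number from compound 2 to compound 3 (0.59 log units; beyond the scatter) when 2,3-difluorobenzyl gives way to the group with two six-membered aromatic rings. The same entering group gives a 1.9-fold lower number from compound 1 to compound 3 (0.28 log units; within the scatter) against the methyl-bearing benzyl group, a step within the scatter. No measurement shown accounts for either step.

As far as these compounds go, what an amide or an alkyl chain on that nitrogen would give stays open, as does whether both aromatic rings of the entering group are needed.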